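Octyloxy ether at the saturated ring carbon: expected potency

The compounds below may be only part of what the source reports. "The series", "measured", "known", "first", "only" and "open" are said of these compounds alone.

Measured so far in a functional assay on HEK293 cells for agonist activity at G-protein coupled receptor 39 (Homo sapiens), read by scintillation proximity assay and inositol phosphate accumulation, with a stated time of 75 min; a lower number here means that less compound is needed, a higher number that more compound is needed for the effect:
compound 1 `Cc1nn(-c2ncnc3nc[nH]c23)c2c1C(c1ccc(OC(C)C)cc1)CC(=O)N2`: 2700 nM
compound 2 `Cc1nn(-c2ncnc3nc[nH]c23)c2c1C(OCCc1ccccc1)CC(=O)N2`: 40 nM
compound 3 `Cc1nn(-c2ncnc3nc[nH]c23)c2c1C(OC(=O)c1ccc(F)cc1)CC(=O)N2`: 245 nM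

Compound 3 sits second highest of the three numbers in this assay. Its nearest neighbour is compound 2, where a 6.1-fold higher number from compound 2 to compound 3 (0.79 log units; beyond the scatter); the furthest is compound 1, where an 11-fold lower number from compound 1 to compound 3 (1.04 log units; beyond the scatter). Compound 1 also relates to compound 2 by a direct step, a 68-fold lower number from compound 1 to compound 2 (1.83 log units; beyond the scatter), the largest in the set.

Compound 4 `CCCCCCCCOC1CC(=O)Nc2c1c(C)nn2-c1ncnc2nc[nH]c12` is unmeasured. It differs from compound 3 as follows: octyl in place of (4-fluorophenyl)carbonyl on an oxygen on a saturated carbon.

Among the measured compounds shown here, the one measured step that bears on this change is the step on the same oxygen from compound 2 to compound 3, in which a 6.1-fold higher number from compound 2 to compound 3 (0.79 log units; beyond the scatter). For the measured compounds named here, compound 4 reverses the carbonyl-bearing substituent for an alkyl group on that oxygen, so the expectation is a move back toward the number of compound 2, though the octyl chain has no ring, unlike phenethyl, and no measured pair speaks to that. A modest step to a lower number is expected, roughly a 3.1-fold lower number from compound 3 to compound 4 (0.49 log units; beyond the scatter), without reaching the full size of the reversed step. Compound 4 is thus estimated at 80 nM in this assay, with a range from 20 nM to 400 nM.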

Compound 4, half-maximal effective concentration: 388 nM
Estimate against measurement, compound 4: 4.9-fold (0.69 log units) below; the range from low to high includes it.
By their numbers in this assay, from the lowest: compound 2; then compounds 3 and 4 (each within the scatter of the next); then compound 1.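

In this assay, octyl in place of (4-fluorophenyl)carbonyl on this oxygen gives a 1.6-fold higher number from compound 3 to compound 4 (0.20 log units; within the scatter), so here a chain with no ring and no carbonyl cannot be told apart from the aromatic ester. The ether link alone does not match compound 2: hexyl in place of phenyl on the chain gives a 9.7-fold higher number from compound 2 to compound 4 (0.99 log units; beyond the scatter), which ties the gap to the end of the substituent rather than to the atom attached to the oxygen. Octyloxy in place of 4-isopropoxyphenyl on the saturated ring carbon gives a 7.0-fold lower number from compound 1 to compound 4 (0.84 log units; beyond the scatter), so all three oxygen-linked groups in compounds 2, 3 and 4 stand apart from compound 1, with no exception among the listed compounds. No measurement at hand explains any of these steps.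

Open, going by these compounds, is how the number responds to chain length and to the distance of the phenyl ring from the oxygen, which a butyl ether, a benzyl ether or a phenylpropyl ether would address. Also open, on these data alone, is whether a chain ending in an amine or a carboxylic acid would fit the same picture.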